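Ester variation on the shared core: compounds 1 to 4

The compounds below may be only part of what the source reports. "The series", "measured", "known", "first", "only" and "open" are said of these compounds alone.

Measured so far:
compound 1, `CC(C)=CC[C@@H](OC(=O)C1CCCO1)C1=CC(=O)c2c(O)ccc(O)c2C1=O`: 10500 nM
compound 2, `CCCC(O)CC(=O)O[C@H](CC=C(C)C)C1=CC(=O)c2c(O)ccc(O)c2C1=O`: > 100000 nM (a limit)
compound 3, `CC(C)=CC[C@@H](OC(=O)C1CCCCO1)C1=CC(=O)c2c(O)ccc(O)c2C1=O`: 24700 nM

In a functional assay on DU-145 cells (Homo sapiens) for cytotoxicity, read by MTT assay (a higher number here means a weaker inhibitor, a lower number a stronger inhibitor), compound 1 gives 10500 nM. For compound 2 the result is a limit of this assay, > 100000 nM, not a number. Compound 3 gives 24700 nM, the highest of the two numbers, and its nearest neighbour is compound 1 with a 2.4-fold higher number from compound 1 to compound 3 (0.37 log units; beyond the scatter). Both steps on the carbonyl carbon that leave the ring intact but change its size stay modest, whereas opening to an acyclic chain is larger: an at least 9.5-fold higher number from compound 1 to compound 2 (0.97 log units; beyond the scatter), and in the other direction an at least 4.0-fold lower number from compound 2 to compound 3 (0.60 log units; beyond the scatter), both of which rest on the limit (the limit of > 100000 nM in this assay, at which 1 of the 3 values shown sits).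

Compound 4, `CCCC(CC(=O)O[C@H](CC=C(C)C)C1=CC(=O)c2c(O)ccc(O)c2C1=O)OC(C)=O`, is the next step from compound 3: 2-acetoxypentyl in place of oxan-2-yl on a carbonyl carbon. Among the measured compounds shown here, the step is again one from a ring to an open chain on the carbonyl carbon, so the steps from compound 1 to compound 2 and from compound 2 to compound 3 bear on it most directly; the acetylated hydroxyl in the chain has no measured counterpart. A higher number, at least modest in size, is therefore expected, with a real chance of another limit. For compound 4 the estimated step is a 2.4-fold higher number from compound 3 to compound 4 (0.39 log units; beyond the scatter). Compound 4 is expected to give about 60000 nM, within a range of 20000 nM to 150000 nM.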

Compound 4, half-maximal inhibitory concentration: 55700 nM
Compound 4: middle estimate off by 1.1-fold (0.03 log units), on the high side, within the range that was stated.
By their numbers in this assay, from the lowest: compound 1; then compound 3; then compound 4. At a limit, above all of these: compound 2.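

In this assay, the open chain on the carbonyl carbon does not by itself push the result to a limit: 2-acetoxypentyl in place of oxan-2-yl gives a 2.3-fold higher number from compound 3 to compound 4 (0.35 log units; beyond the scatter), and 2-acetoxypentyl in place of oxolan-2-yl gives a 5.3-fold higher number from compound 1 to compound 4 (0.72 log units; beyond the scatter), so both ring compounds keep the lower numbers and a ring-to-chain cost can now be read as a number. Acetyl in place of hydrogen on an oxygen on a saturated carbon gives an at least 1.7-fold lower number from compound 2 to compound 4 (0.25 log units; that floor lies within the scatter), so the data do not establish that acetylating the chain hydroxyl changes the result. Compound 2 is a limit and not a number, so the real size of that step stays unknown: the limit of > 100000 nM in this assay, at which 1 of the 4 values shown sits.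

Still open, on these data alone, is whether the ring oxygen matters, since a cyclopentyl or cyclohexyl group on the carbonyl carbon would separate the effect of the ring from that of its oxygen. Also open, as far as these compounds go, is how a longer chain than 2-acetoxypentyl, or an amine or a carboxylic acid on the chain, would read in this assay.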